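Working notes: compound 2 to compound 3

A few compounds are considered here, and "the series" means these few. Any claim that something is new, unique, unknown or untested is made for them only; others in the source may bear on it.

Within the data shown here, compound 1 `O=C(/C=C/c1coc2cc(O)ccc2c1=O)NCc1ccc(F)cc1` and compound 2 `COc1ccc2c(=O)c(/C=C/C(=O)NCc3cccc(F)c3)coc2c1` are the two measured members of this set. In a functional assay on L02 cells (Homo sapiens) for inhibition, read by MTT assay, with a stated time of 48 h (a higher number here means a weaker inhibitor, a lower number a stronger inhibitor), compound 1 gives > 200000 nM, which is a limit of the assay and not a number. In this assay compound 2 gives > 200000 nM, again a limit rather than a measured number. Compound 2 therefore stands at the limit of > 200000 nM in this assay, at which 2 of the 2 values shown sit; the numbers shown do not separate it from compound 1, and no step between the two is measured.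

Compound 3 `COc1ccc(CNC(=O)/C=C/c2coc3cc(OC)ccc3c2=O)cc1` is not yet measured in this assay. It differs from compound 2 in one place: 4-methoxyphenyl in place of 3-fluorophenyl on a saturated chain carbon bound to an amide-type nitrogen. Among the measured compounds shown here, no measured step exists in this set from which the size or direction of such a change could be read. The expected step from compound 2 to compound 3 in this assay is a step that the limit leaves unreadable from compound 2 to compound 3, that is none beyond the scatter, and the most probable outcome is once more a limit rather than a number. Compound 3 in this assay is estimated at 250000 nM, with a range from 100000 nM to 1000000 nM.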

Compound 3, half-maximal inhibitory concentration: > 200000 nM
Compound 3: a limit, no number; the forecaster's own chance of this, stated with the estimate: 85%; the middle value does not contradict the limit.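

Among these compounds, compound 2 and compound 3 both give limits rather than numbers in this assay, so no step from one to the other can be read. The compounds shown leave open whether 4-methoxyphenyl and 3-fluorophenyl differ at all at this place in this assay, and whether any member of the series gives a measurable value there.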